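A few compounds are considered here, and "the series" means these few. Any claim that something is new, unique, unknown or untested is made for them only; others in the source may bear on it.

Measured so far:
compound 1 `COc1cc2cc(Oc3ccc(NC(=O)Nc4ccc(C)cc4)cc3)c(C)nc2cc1OC`: 99.9%
compound 2 `COc1cc2cc(Oc3ccc(NC(=O)Nc4cccc(C(F)(F)F)c4)cc3)c(C)nc2cc1OC`: -85.7%
compound 3 `COc1cc2cc(Oc3ccc(NC(=O)Nc4ccc(Cl)c(C(F)(F)F)c4)cc3)c(C)nc2cc1OC`: -80.4%

In a functional assay on U-251 cells (Homo sapiens) for inhibition, read by sulforhodamine B assay, with a stated time of 48 h, tested at 10 uM (on this read-out lower numbers stand for a stronger effect and higher numbers for a weaker effect at the one concentration tested), compound 1 stands highest of the three, so it shows the weakest effect at the tested concentration. Compound 4 `COc1cc2cc(Oc3ccc(NC(=O)Nc4ccc(Cl)c(Cl)c4)cc3)c(C)nc2cc1OC` differs from compound 1 by 3,4-dichlorophenyl in place of 4-methylphenyl on an amide-type nitrogen. Two measured steps from compound 1 bear on this: a number 185.6 percentage points lower from compound 1 to compound 2 (beyond the scatter) and a number 180.3 percentage points lower from compound 1 to compound 3 (beyond the scatter); both swap the 4-methylphenyl for a trifluoromethyl-bearing ring and both fall far beyond the scatter. Within that pair, a number 5.3 percentage points higher from compound 2 to compound 3 (within the scatter), so adding chloro changed little. Because a number 180.3 percentage points lower from compound 1 to compound 3 (beyond the scatter) already covers a chloro-bearing ring, a large drop is expected for compound 4 as well, a number 159.9 percentage points lower from compound 1 to compound 4 (beyond the scatter). Compound 4 is therefore estimated at -60%, with a range from -100% to 10%.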

Compound 4, a percentage reported as activity, at one concentration (the size of the read-out at that concentration, not a potency): -32.3%
The estimate for compound 4 lay 27.7 percentage points below the measured number, within the range that was stated.
By their numbers in this assay, from the lowest: compounds 2 and 3 (each within the scatter of the next); then compound 4; then compound 1.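

In this assay, a large drop does not need a trifluoromethyl group, as the 3,4-dichlorophenyl group alone gives one (a number 132.2 percentage points lower from compound 1 to compound 4 (beyond the scatter)). The two trifluoromethyl-bearing rings still show a stronger effect than this ring (a number 48.1 percentage points higher from compound 3 to compound 4 (beyond the scatter); a number 53.4 percentage points higher from compound 2 to compound 4 (beyond the scatter)), so swapping chloro for trifluoromethyl on this ring matters. No measurement shown here explains that gap.

The compounds shown leave open how a ring carrying a single chloro group would compare. They also leave open what an amine or a carboxylic acid on this ring would do.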